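The compounds below may be only part of what the source reports. "The series", "measured", "known", "first", "only" and "open" are said of these compounds alone.

In an ADME assay on the whole organism (strain Balb) for pharmacokinetics, with Mus musculus as the target, at a dose of 10 mg/kg by the oral route (on this read-out lower numbers stand for lower exposure and higher numbers for higher exposure at the dose given), compound 2 (`CCc1ccc(Cl)cc1-c1[nH]c(-c2ccnc(N)n2)cc1C(N)=O`) gives 600 nM and is the lower of the two numbers at hand, while compound 1 (`NC(=O)c1cc(-c2ccnc(N)n2)[nH]c1-c1cc(C(F)(F)F)ccc1Cl`) gives 4200 nM and lies clear of it beyond the usual scatter. Compound 3 (`CCc1ccc(C(F)(F)F)cc1-c1[nH]c(-c2ccnc(N)n2)cc1C(N)=O`) carries trifluoromethyl in place of chloro on an aromatic carbon, para to an ethyl group and meta to a large group, a change that comes to trifluoromethyl in place of chloro on an aromatic carbon in all. Among the measured compounds shown here, no measured pair shows this change alone, so the data give no direct size for it. Compound 1 also bears trifluoromethyl and gives 4200 nM as the only hint available, so a modest rise rather than a fall is expected in this assay for this change. The expected move is a 1.7-fold higher number from compound 2 to compound 3 (0.22 log units; within the scatter) and would stay within the scatter. For compound 3 the estimate is 1000 nM with an expected range from 300 nM to 3000 nM at this dose.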

Compound 3, maximal plasma concentration: 4400 nM
Compound 3: middle estimate off by 4.4-fold (0.64 log units), on the low side; measured number outside the range, above it.
By their numbers in this assay, from the lowest: compound 2; then compounds 1 and 3 (each within the scatter of the next).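

In this assay the change from chloro to trifluoromethyl on an aromatic carbon, para to an ethyl group, now has a measured size, a 7.3-fold higher number from compound 2 to compound 3 (0.87 log units; beyond the scatter), so this position clearly matters for the read-out. With trifluoromethyl held in place, ethyl in place of chloro on an aromatic carbon gives a 1.0-fold higher number from compound 1 to compound 3 (0.02 log units; within the scatter), so that exchange does not separate the two compounds beyond the scatter. No measurement at hand gives a reason for the step at the trifluoromethyl position.

The compounds shown leave open how a nitrile, a methoxy group or an amine would fare at the position that carries trifluoromethyl in compound 3. They also leave open whether a longer chain in place of the ethyl group would keep the number close to those of compound 1 and compound 3.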